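Ether side chain variation on the shared core

The compounds below may be only part of what the source reports. "The series", "measured", "known", "first", "only" and "open" are said of these compounds alone.

Compound 1 `Nc1ccc2cccc(OCC3CCCC3)c2n1` gives 53 nM in an assay on cells with melanin-concentrating hormone receptor 1 (Homo sapiens) as the target, read by radioligand binding; a lower number here means a stronger inhibitor, a higher number a weaker inhibitor. Among the measured compounds shown here, compound 2 `CC1CC1COc1cccc2ccc(N)nc12` gives 1640 nM in this assay and stands as the highest of the two numbers measured so far; its only neighbour is compound 1, and the step of a 31-fold higher number from compound 1 to compound 2 (1.49 log units; beyond the scatter) is large, well beyond the scatter. Compound 3 `CSCCOc1cccc2ccc(N)nc12` has not yet been measured in this assay. The change from compound 2 to compound 3 is (methylsulfanyl)methyl in place of 2-methylcyclopropyl on a saturated chain carbon bound to an oxygen on an aromatic ring. For the measured compounds named here, only one measured step bears on it, the step of a 31-fold higher number from compound 1 to compound 2 (1.49 log units; beyond the scatter), which sits at the same place and shows that shrinking the group there from cyclopentyl to 2-methylcyclopropyl costs a great deal. Going by the values given here, no measured step involves an open chain or a sulfur at this place, so the direction of the change to (methylsulfanyl)methyl rests on size alone: the group entering is of similar bulk to the one leaving, and the step of a 1.2-fold higher number from compound 2 to compound 3 (0.09 log units; within the scatter) is expected to stay within the scatter. Compound 3 is therefore estimated at 2000 nM, with a range of 500 nM to 8000 nM in this assay.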

Compound 3, half-maximal inhibitory concentration: > 2000 nM
Compound 3: no number, only a limit; the forecaster's own chance of this, stated with the estimate: 5%; the middle value sits exactly at the limit.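

Compound 3 carries a limit and not a number: the limit of > 2000 nM in this assay, at which 1 of the 3 values shown sits. The step of an at least 37-fold higher number from compound 1 to compound 3 (1.57 log units; beyond the scatter) shows that the loss against compound 1 is not confined to the 2-methylcyclopropyl group: an open chain with a sulfur in it, 2-(methylsulfanyl)ethyl, also stands far from the cyclopentyl-bearing compound, so two different replacements at this place now fall well short of compound 1 in this assay. The other step, an at least 1.2-fold higher number from compound 2 to compound 3 (0.08 log units; that floor lies within the scatter), is only a floor that lies within the scatter, so it fixes no order between the two compounds and leaves the true size of this change unknown.

The compounds shown do not separate the part played by the sulfur from that of the open chain or of the ring that leaves, since the entering and leaving groups differ in all of these at once. On these data alone, whether a plain propyl chain, a methoxy group in place of methylsulfanyl, or a larger ring such as cyclohexyl at this place would come back towards compound 1 stays open.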